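Cinnamoyl hydrazide series: swapping methoxy for chloro

A few compounds are considered here, and "the series" means these few. Any claim that something is new, unique, unknown or untested is made for them only; others in the source may bear on it.

Measured so far:
compound 1, `Cc1nc2ccccc2c(=O)n1NC(=O)/C(Cl)=C/c1ccccc1`, 20 nM in a functional assay on NCI-H460 cells (Homo sapiens) for inhibition, read by sulforhodamine B assay, with a stated time of 48 h; a lower number here means a stronger inhibitor of growth, a higher number a weaker inhibitor of growth
compound 2, `COc1ccc(/C=C(\Cl)C(=O)Nn2c(C)nc3ccccc3c2=O)cc1`, 600 nM

For the measured compounds named here, compound 2 stands highest of the two numbers; the only step, a 30-fold higher number from compound 1 to compound 2 (1.48 log units; beyond the scatter), is large and well beyond the scatter. Compound 3, `Cc1nc2ccccc2c(=O)n1NC(=O)/C(Cl)=C/c1ccc(Cl)cc1`, differs from compound 2 by chloro in place of methoxy on an aromatic carbon. Going by the values given here, no measured step covers methoxy against chloro, so the expectation rests on the single step from compound 1 to compound 2 alone, which shows the substituent at this place matters greatly. Compound 3 is expected to fall between the two measured numbers, estimated at 110 nM (range 20 nM to 700 nM), a step of a 5.5-fold lower number from compound 2 to compound 3 (0.74 log units; beyond the scatter).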

Compound 3, concentration for 50% growth inhibition: 38900 nM
Beside the measured number, compound 3's estimate is 350-fold (2.55 log units) below it, and the stated range ends below it.
By their numbers in this assay, from the lowest: compound 1; then compound 2; then compound 3.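

Neither substituent at this aromatic carbon matches hydrogen in this assay, and the two differ sharply from each other: chloro gives a 1900-fold higher number from compound 1 to compound 3 (3.29 log units; beyond the scatter), and replacing methoxy with chloro gives a 65-fold higher number from compound 2 to compound 3 (1.81 log units; beyond the scatter). The loss is therefore specific to the group and not a single penalty for any substituent here. Chloro has fewer heavy atoms than methoxy, yet its number lies further from that of compound 1, so heavy-atom count does not order these three compounds. Nothing available explains this order. Still open, on these data alone, is how an amine, a carboxylic acid or a fluorine at this carbon would compare, and whether chloro behaves alike elsewhere on the ring.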